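Pyridinone series: removal of the acetamidomethyl group

The source may report more compounds than this note shows. Statements on the series, on what has been measured and on what is new or still open speak of the compounds shown alone.

Measured compounds:
- compound 1 `CCCCc1ccc(CNC(C)=O)c(=O)n1Cc1ccc(-c2ccccc2-c2nn[nH]n2)cc1`: 3 nM
- compound 2 `CCCCc1ccc(CN(Cc2ccccc2)S(=O)(=O)c2ccc(C)cc2)c(=O)n1Cc1ccc(-c2ccccc2-c2nn[nH]n2)cc1`: 60 nM
- compound 3 `CCCCc1ccc(CN(C)S(C)(=O)=O)c(=O)n1Cc1ccc(-c2ccccc2-c2nn[nH]n2)cc1`: 0.2 nM

In a functional assay (aorta) for antagonist activity, with Oryctolagus cuniculus as the target (on this read-out higher numbers stand for weaker inhibition and lower numbers for stronger inhibition), compound 1 stands second highest of the three numbers, with compound 3 giving 0.2 nM and compound 2 giving 60 nM. Compound 4 `CCCCc1cccc(=O)n1Cc1ccc(-c2ccccc2-c2nn[nH]n2)cc1` has not been measured; it differs from compound 1 as follows: hydrogen in place of acetamidomethyl on an aromatic carbon. Within the data shown here, no measured step removes this side chain outright. The nearest comparison is a 15-fold lower number from compound 1 to compound 3 (1.18 log units; beyond the scatter), which shows that changes at this position move the number strongly; the values of compound 1 and compound 2 point the same way. A shift beyond the scatter in this assay is therefore expected, more likely upward. For compound 4 the estimate is 20 nM, range 3 nM to 150 nM, a step of a 6.7-fold higher number from compound 1 to compound 4 (0.82 log units; beyond the scatter).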

Compound 4, half-maximal inhibitory concentration: 4 nM
Beside the measured number, compound 4's estimate is 5.0-fold (0.70 log units) above it; the range from low to high includes it.
By their numbers in this assay, from the lowest: compound 3; then compounds 1 and 4 (each within the scatter of the next); then compound 2.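

In this assay, the acetamidomethyl group can be removed with no change beyond the scatter (a 1.3-fold higher number from compound 1 to compound 4 (0.12 log units; within the scatter)). The side chain of compound 1 is therefore not needed for its number, whereas (methyl(methylsulfonyl)amino)methyl does matter at this position (a 20-fold higher number from compound 3 to compound 4 (1.30 log units; beyond the scatter)). No evidence on hand bears on either step.

Open, on these data alone, is whether the methylsulfonyl group or the nitrogen methyl carries the difference between compound 3 and compound 4. Also open, as far as these compounds go, is how a primary amine or a carboxylic acid on this aromatic carbon would compare with hydrogen.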